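The source may report more compounds than this note shows. Statements on the series, on what has been measured and on what is new or still open speak of the compounds shown alone.

Working notes on the series.

Three analogues carrying the same thiazolidinedione-bearing core have been measured in a functional assay on the whole organism (plasma, strain Wistar) with Rattus norvegicus as the target, with a stated time of 15 days, at a dose of 100 mg/kg by the oral route; on this read-out lower numbers stand for a weaker effect and higher numbers for a stronger effect at the one dose given. Compound 1 `Cc1ccc(-c2nnc(SCCOc3ccc(/C=C4\SC(=O)NC4=O)cc3)[nH]2)cc1` gives 29.7%. Compound 2 `O=C1NC(=O)/C(=C/c2ccc(OCCSc3nnc(-c4ccccc4[N+](=O)[O-])[nH]3)cc2)S1` gives 26.8%, and the change between them is a number 2.9 percentage points lower from compound 1 to compound 2 (within the scatter). Compound 3 `O=C1NC(=O)/C(=C/c2ccc(OCCSc3nnc(Cc4ccccc4)o3)cc2)S1` gives 23.1%, the lowest of the three numbers, though its gaps to compound 2 and to compound 1 both lie within the scatter, so no order among the three can be read from these values.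

Compound 4 `O=C1NC(=O)/C(=C/c2ccc(OCCSc3nnc(-c4ccncc4)o3)cc2)S1` differs from compound 3 only in one place: pyridin-4-yl in place of benzyl on an aromatic carbon. Within the data shown here, no measured step covers this exchange on this core; the only measured step, from compound 1 to compound 2, is an aryl swap on a different five-membered ring and stayed within the scatter. On that basis no step beyond the scatter is expected in this assay, in either direction. The estimate for compound 4 is therefore 25%, within 14% to 36%, which corresponds to an expected step of a number 1.9 percentage points higher from compound 3 to compound 4 (within the scatter).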

Compound 4, a percentage reported as activity, at one dose (the size of the read-out at that dose, not a potency): 43.4%
The estimate for compound 4 lay 18.4 percentage points below the measured number, and the stated range ends below it.
By their numbers in this assay, from the lowest: compounds 3, 2 and 1 (each within the scatter of the next); then compound 4.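

Among these compounds, the place on the aromatic carbon of the five-membered aromatic ring with 2 nitrogen and 1 oxygen responds to its substituent in this assay: pyridin-4-yl in place of benzyl gives a number 20.3 percentage points higher from compound 3 to compound 4 (beyond the scatter), the first single exchange to go beyond the scatter. The exchange changes two things at once, as the entering group carries a ring nitrogen with 1 hydrogen-bond acceptor and has 6 heavy atoms against 7 in benzyl, so this one step cannot separate the two. No measurement at hand explains the gain.

The compounds shown leave open whether a plain phenyl group at this place would match pyridin-4-yl or benzyl, and so which part of the exchange carries the step. Also open, from the compounds shown here alone, are whether pyridin-3-yl or pyridin-2-yl would behave like pyridin-4-yl, and whether pyridin-4-yl would give a similar step on the core of compound 1.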